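This account rests on a few compounds, and the source may have more. Where it says the series, first, only, none or still open, it means among the compounds named here.

In a functional assay on HCT-116 cells (Homo sapiens) for cytotoxicity, read by MTT assay, with a stated time of 48 h (a lower number here means a stronger inhibitor, a higher number a weaker inhibitor), three compounds that share one core and differ only in the aryl group on a saturated ring carbon have been measured. Compound 1 `COc1cc(/C=C/C(=O)C2=C(/C=C/c3ccc(O)c(OC)c3)NC(=O)NC2c2ccccc2O)ccc1O`, with 2-hydroxyphenyl at that place, gives 100000 nM. Compound 2 `COc1cc(/C=C/C(=O)C2=C(/C=C/c3ccc(O)c(OC)c3)NC(=O)NC2c2ccc(O)cc2)ccc1O`, with 4-hydroxyphenyl, gives 100000 nM. Compound 3 `COc1cc(/C=C/C(=O)C2=C(/C=C/c3ccc(O)c(OC)c3)NC(=O)NC2c2c(Cl)cccc2Cl)ccc1O`, with 2,6-dichlorophenyl, gives 50000 nM, a value within the scatter of both others, so it stands apart from neither.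

Compound 4 `COc1cc(/C=C/C(=O)C2=C(/C=C/c3ccc(O)c(OC)c3)NC(=O)NC2c2cccc([N+](=O)[O-])c2)ccc1O` keeps the core and carries 3-nitrophenyl in place of the 2,6-dichlorophenyl of compound 3: 3-nitrophenyl in place of 2,6-dichlorophenyl on a saturated ring carbon.

The measured steps that bear on this change are those at the same place: no change at the digits printed from compound 1 to compound 2 (within the scatter), a 2.0-fold lower number from compound 1 to compound 3 (0.30 log units; within the scatter) and a 2.0-fold lower number from compound 2 to compound 3 (0.30 log units; within the scatter). All three lie within the scatter, even though the groups exchanged include both hydroxyphenyl and dichlorophenyl. Among the compounds with values here, no measured compound carries a nitro group, so the data give no direct reading for 3-nitrophenyl, and this expectation rests only on those three steps. No step beyond the scatter is therefore expected in this assay. The estimated change is a 1.2-fold higher number from compound 3 to compound 4 (0.08 log units; within the scatter). Compound 4 is expected at about 60000 nM, with an estimated range of 25000 nM to 120000 nM.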

Compound 4, half-maximal inhibitory concentration: 50000 nM
For compound 4 the middle estimate is 1.2-fold (0.08 log units) above the measured one; the range from low to high includes it.
By their numbers in this assay, from the lowest: compounds 3, 4, 1 and 2 (each within the scatter of the next).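

In this assay, putting 3-nitrophenyl in place of 2,6-dichlorophenyl on the saturated ring carbon gives no change at the digits printed from compound 3 to compound 4 (within the scatter), even though the entering group brings a nitro group, with 2 hydrogen-bond acceptors against 0 in the group that leaves. Set against the two hydroxyphenyl compounds, the same group gives a 2.0-fold lower number from compound 2 to compound 4 (0.30 log units; within the scatter) and a 2.0-fold lower number from compound 1 to compound 4 (0.30 log units; within the scatter), so it stands apart from neither of them. With a nitro-bearing ring now added to the hydroxyl-bearing and chlorine-bearing rings, all four aryl groups at this position lie within the scatter of one another, and nothing at hand accounts for this.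

The compounds shown leave open whether an amine or a carboxylic acid on this aryl ring, or a longer alkyl chain in place of the ring, would give a number beyond the scatter at this position. They also leave open whether replacing the 2-(4-hydroxy-3-methoxyphenyl)ethenyl group, which all four compounds share, would move the number in this assay, since only the aryl group varies here.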